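Replacing the pyridin-4-ylamino arm of compound 3 with an isopentylamino arm

The source may report more compounds than this note shows. Statements on the series, on what has been measured and on what is new or still open speak of the compounds shown alone.

Of the compounds shown here, three sharing one core have been measured in a physicochemical assay for lipophilicity, read by HPLC; on this read-out lower numbers stand for lower lipophilicity and higher numbers for higher lipophilicity. Compound 1 `CC(=O)NC[C@H]1CN(c2ccc(OC[C@@H](O)CNc3ccccc3)c(F)c2)C(=O)O1` gives 1.42. Compound 2 `CC(=O)NC[C@H]1CN(c2ccc(OC[C@@H](O)CNc3ccncc3)c(F)c2)C(=O)O1` gives -0.04, and compound 3 `CC(=O)NC[C@H]1CN(c2ccc(OC[C@H](O)CNc3ccncc3)c(F)c2)C(=O)O1` gives 0.02. Compound 3 thus stands second highest of the three; compound 2 is within the scatter of it, while compound 1 lies clearly above. The two large steps recorded are a number 1.46 log units lower from compound 1 to compound 2 (beyond the scatter) and a number 1.40 log units lower from compound 1 to compound 3 (beyond the scatter), and the small step of a number 0.06 log units higher from compound 2 to compound 3 (within the scatter) is within the scatter, consistent with the fact that compounds 2 and 3 differ only in the configuration as drawn.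

Compound 4 `CC(=O)NC[C@H]1CN(c2ccc(OC[C@@H](O)CNCCC(C)C)c(F)c2)C(=O)O1` has not yet been measured in this assay. It differs from compound 3 as follows: 1-hydroxy-2-(isopentylamino)ethyl in place of 1-hydroxy-2-((pyridin-4-yl)amino)ethyl on a saturated chain carbon bound to an oxygen on an aromatic ring. Within the data shown here, no measured pair shows a swap of an aromatic amine arm for an open-chain alkylamine arm, so the only bearing steps are those from compound 1, where the aromatic ring carrying one hetero atom sat far lower than the all-carbon ring. Moving away from the pyridin-4-yl group is therefore expected to raise the number, though how much of the gap to compound 1 is recovered is uncertain. Compound 4 is expected to reach about 0.9, between 0.1 and 1.7, an expected step of a number 0.88 log units higher from compound 3 to compound 4 (beyond the scatter).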

Compound 4, partition coefficient: 1.17
Beside the measured number, compound 4's estimate is 0.27 log units below it; low and high end bracket the measured number.
By their numbers in this assay, from the lowest: compounds 2 and 3 (each within the scatter of the next); then compounds 4 and 1 (each within the scatter of the next).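

In this assay, the isopentyl arm parts clearly from both pyridin-4-yl compounds (a number 1.21 log units higher from compound 2 to compound 4 (beyond the scatter); a number 1.15 log units higher from compound 3 to compound 4 (beyond the scatter)), so the low numbers of compounds 2 and 3 are not shared by every replacement for phenyl on the amine nitrogen. Set against the phenyl arm, the same chain gives a difference that cannot be told from repeated measurement (a number 0.25 log units lower from compound 1 to compound 4 (within the scatter)), which shows that at this position a group with no ring can match an all-carbon aromatic ring on this read-out, and that an aromatic ring alone does not set the number. The two large steps to compound 4 can be read as one finding, since their starting points stand together and the stereocentre on the saturated chain carbon does not separate them on this read-out: (the fact that compounds 2 and 3 differ only in the configuration as drawn).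

Why the pyridin-4-yl arm sits so low remains unexplained by these compounds, and the pyridin-3-yl and pyridin-2-yl arms would test whether the place of the ring nitrogen matters. From the compounds shown here alone, it is also open whether a cyclohexyl ring, a shorter chain such as ethyl, or a chain ending in a hydroxyl or carboxylic acid would follow isopentyl or fall towards compounds 2 and 3.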